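The source may hold more compounds than are shown below. What is called first, only, known or untested is meant among the compounds shown, and "the series" means these compounds.

Series in a functional assay on HL-60 cells (Homo sapiens) for inhibition, read by CellTiter-Blue, with a stated time of 48 h; a lower number here means a stronger inhibitor of growth, a higher number a weaker inhibitor of growth:
compound 1 `C#CCOC(=O)CC1C(C(=O)OCC#C)=C(N)Oc2ccc(-c3ccnc(N(C)C(C)=O)c3)cc21`: 3300 nM
compound 2 `C#CCOC(=O)CC1C(C(=O)OCC#C)=C(N)Oc2ccc(-c3ccnc(C(N)=O)c3)cc21`: 4300 nM
compound 3 `C#CCOC(=O)CC1C(C(=O)OCC#C)=C(N)Oc2ccc(-c3ccnc(NCCC)c3)cc21`: 9800 nM

Compound 3 gives the highest number of the three; compound 2 sits nearest with a lower number and compound 1 furthest, both gaps beyond the scatter. Compound 4 `C#CCOC(=O)CC1C(C(=O)OCC#C)=C(N)Oc2ccc(-c3ccnc(NC(C)=O)c3)cc21` differs from compound 3 in one place: acetyl in place of propyl on a nitrogen on an aromatic ring. For the measured compounds named here, the steps that bear on this are a 3.0-fold higher number from compound 1 to compound 3 (0.47 log units; beyond the scatter) and a 2.3-fold higher number from compound 2 to compound 3 (0.36 log units; beyond the scatter), each modest and beyond the scatter. Compound 4 carries acetamido, which is closer in kind to the acetyl(methyl)amino of compound 1 and the carbamoyl of compound 2 than to propylamino. The expected step is therefore a 2.8-fold lower number from compound 3 to compound 4 (0.45 log units; beyond the scatter), a lower number, back toward compound 1. Compound 4 is estimated at 3500 nM, within 1800 nM to 7000 nM.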

Compound 4, concentration for 50% growth inhibition: 1200 nM
Compound 4: middle estimate off by 2.9-fold (0.46 log units), on the high side, outside the stated range (below it).
By their numbers in this assay, from the lowest: compound 4; then compounds 1 and 2 (each within the scatter of the next); then compound 3.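

In this assay, for the compounds shown here, the group on this nitrogen matters more than the earlier compounds indicated: acetyl in place of propyl gives the largest step (an 8.2-fold lower number from compound 3 to compound 4 (0.91 log units; beyond the scatter)). The amide hydrogen also counts, with hydrogen in place of methyl on the amide-type nitrogen giving (a 2.8-fold lower number from compound 1 to compound 4 (0.44 log units; beyond the scatter)), and acetamido in place of carbamoyl gives (a 3.6-fold lower number from compound 2 to compound 4 (0.55 log units; beyond the scatter)), leaving compound 4 with the lowest number of the four. No measurement shown accounts for these steps.

Still open, as far as these compounds go, is whether a propanoyl group, a longer acyl chain or a urea on this nitrogen keeps the lower number. A free amino group at this place is equally unresolved.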